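The source may report more compounds than this note shows. Statements on the series, on what has been measured and on what is new or still open speak of the compounds shown alone.

The series keeps one core and varies only the aryl group on the amine nitrogen. Compound 1 `COc1ccc(N/C=C\C(=O)c2nc(-c3ccc(C(F)(F)F)cc3)n3ccccc23)cc1OC` carries 3,4-dimethoxyphenyl there; in a functional assay on HCT-116 cells (Homo sapiens) for cytotoxicity, read by MTT assay, with a stated time of 48 h (a higher number here means a weaker inhibitor, a lower number a stronger inhibitor), compound 1 gives > 30000 nM, which is a limit of the assay and not a number. Compound 2 `O=C(/C=C\Nc1ccc2cc[nH]c2c1)c1nc(-c2ccc(C(F)(F)F)cc2)n2ccccc12` carries 1H-indol-6-yl; in this assay compound 2 gives > 30000 nM, again a limit. For the measured compounds named here, compound 3 `O=C(/C=C\Nc1ccc(Cl)cc1)c1nc(-c2ccc(C(F)(F)F)cc2)n2ccccc12` carries 4-chlorophenyl and in this assay gives 11500 nM, the only number in the set. The step from compound 1 to compound 2 cannot be read: a step that the two limits leave unreadable from compound 1 to compound 2. The two steps towards compound 3 are readable at one end only, an at least 2.6-fold lower number from compound 1 to compound 3 (0.41 log units; beyond the scatter) and an at least 2.6-fold lower number from compound 2 to compound 3 (0.41 log units; beyond the scatter), both set against (the limit of > 30000 nM in this assay, at which 2 of the 3 values shown sit).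

Compound 4 `O=C(/C=C\Nc1ccc(F)cc1)c1nc(-c2ccc(C(F)(F)F)cc2)n2ccccc12` differs from compound 3 by fluoro in place of chloro on an aromatic carbon. Going by the values given here, no measured step exchanges one halogen for another; the two readable steps both run from 3,4-dimethoxyphenyl or 1H-indol-6-yl to 4-chlorophenyl, and compound 3 itself sits not far from the limit. Compound 4 is therefore expected to show a step of about a 1.7-fold higher number from compound 3 to compound 4 (0.24 log units; within the scatter), towards a higher number, with a real chance that only a limit is returned in this assay. Compound 4 is estimated at 20000 nM, between 8000 nM and 45000 nM.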

Compound 4, half-maximal inhibitory concentration: > 30000 nM
Compound 4: a limit, no number (the forecaster's own chance of this, stated with the estimate: 45%); at least 1.5-fold (0.17 log units) between middle value and limit.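

For the compounds shown here, exchanging chloro for fluoro on an aromatic carbon, para to a large group, is the first halogen exchange, and in this assay it gives an at least 2.6-fold higher number from compound 3 to compound 4 (0.41 log units; beyond the scatter). This position therefore responds to a change of one heavy atom, with no ring, hydrogen-bond donor, hydrogen-bond acceptor or net charge involved on either side, and among the four aryl groups shown only 4-chlorophenyl gives a number, while 4-fluorophenyl joins 3,4-dimethoxyphenyl and 1H-indol-6-yl at a limit. The steps from compound 1 and from compound 2 to compound 4 cannot be read, so the aryl groups other than 4-chlorophenyl remain unranked, and the series is now held mainly at one ceiling: the limit of > 30000 nM in this assay, at which 3 of the 4 values shown sit.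

On these data alone, how far compound 4 lies past its limit stays open, and with it the full size of the halogen step. Also open, as far as these compounds go, is whether bromo, methyl or nitrile at the same place would give a number in this assay, and whether a chloro group elsewhere on the ring would keep the reading seen for compound 3.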